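Fluoro to bromo in the 3-fluorophenyl compounds

The source may report more compounds than this note shows. Statements on the series, on what has been measured and on what is new or still open speak of the compounds shown alone.

Measured in a functional assay on NCI-N87 cells (Homo sapiens) for antiproliferative activity; on this read-out lower numbers stand for stronger inhibition and higher numbers for weaker inhibition:
- compound 1 `C#Cc1cccc(Nc2ncnn3ccc(CN4CCC(N)CC4)c23)c1`: 120 nM
- compound 2 `NC1CCN(Cc2ccn3ncnc(Nc4cccc(F)c4)c23)CC1`: 280 nM

Of these two, compound 2 carries the higher number, 280 nM. Compound 3 `NC1CCN(Cc2ccn3ncnc(Nc4cccc(Br)c4)c23)CC1` differs from compound 2 by bromo in place of fluoro on an aromatic carbon. For the measured compounds named here, the one measured step bearing on this place is a 2.3-fold higher number from compound 1 to compound 2 (0.37 log units; beyond the scatter), modest and with fluoro in place of ethynyl. No bromo value exists yet, so only a small move toward a lower number in this assay is expected, possibly within the scatter. The estimated change is a 1.6-fold lower number from compound 2 to compound 3 (0.22 log units; within the scatter). Compound 3 is expected at 170 nM, with an estimated range of 70 nM to 400 nM.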

Compound 3, half-maximal inhibitory concentration: 50 nM
The estimate for compound 3 lay 3.4-fold (0.53 log units) above the measured number; measured number outside the range, below it.
By their numbers in this assay, from the lowest: compound 3; then compound 1; then compound 2.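

In this assay, for the compounds shown here, the identity of the halogen on this aromatic carbon matters more than the single earlier step suggested: bromo in place of fluoro gives (a 5.6-fold lower number from compound 2 to compound 3 (0.75 log units; beyond the scatter)). Bromo also overtakes ethynyl (a 2.4-fold lower number from compound 1 to compound 3 (0.38 log units; beyond the scatter)), so ethynyl no longer gives the lowest number at this place. Nothing measured accounts for this gain.

Open, from the compounds shown here alone, is whether chloro or iodo would fall in line with the order seen for fluoro and bromo. Also open, going by these compounds, is whether the bromo gain would survive a different amine on the shared core.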